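A few compounds are considered here, and "the series" means these few. Any claim that something is new, unique, unknown or untested is made for them only; others in the source may bear on it.

Compound 1 `COC(=O)c1cccc(OCc2oc(-c3cccc(OC)c3)nc2C)c1` and compound 2 `COC(=O)c1ccc(OCc2oc(-c3cccc(OC)c3)nc2C)cc1` share one core and differ only in where the methoxycarbonyl group sits. In an assay on cells for antagonist activity at vitamin D3 receptor (Homo sapiens), read by a luciferase reporter (on this read-out higher numbers stand for weaker inhibition and lower numbers for stronger inhibition), compound 1 gives 17100 nM, and compound 2 gives 8890 nM; the two numbers lie within the usual scatter of each other, so neither can be set apart. Compound 3 `COC(=O)CCc1ccc(OCc2oc(-c3cccc(OC)c3)nc2C)cc1` carries 2-(methoxycarbonyl)ethyl in place of methoxycarbonyl on an aromatic carbon. Among the compounds with values here, with no comparable pair measured, the expected step from compound 2 to compound 3 is a 1.0-fold higher number from compound 2 to compound 3 (0.01 log units; within the scatter), nothing beyond the scatter. Compound 3 is therefore estimated at 9000 nM, in a range from 3000 nM to 27000 nM.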

Compound 3, half-maximal inhibitory concentration: 6700 nM
Compound 3: the middle estimate sits 1.3-fold (0.13 log units) above what was measured; measured number inside the range.
By their numbers in this assay, from the lowest: compounds 3, 2 and 1 (each within the scatter of the next, the first and the last beyond it).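

In this assay putting 2-(methoxycarbonyl)ethyl in place of methoxycarbonyl on this aromatic carbon, para to a large group, gives a 1.3-fold lower number from compound 2 to compound 3 (0.12 log units; within the scatter) and so shows that the longer group is accepted here without a change that stands out from the scatter. No available measurement offers a reason for this result.

Going by these compounds, it remains open whether the ester itself matters, which a carboxylic acid or an amide in its place could test. A longer chain could show how much further this position can be extended before the number moves.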